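A pyridine gives way to an aminopyrazine on a fused core

The source may hold more compounds than are shown below. What is called first, only, known or untested is meant among the compounds shown, and "the series" means these compounds.

Measured so far, in a functional assay on AGS cells (Homo sapiens) for cytotoxicity, read by MTT assay, with a stated time of 48 h; a higher number here means a weaker inhibitor, a lower number a stronger inhibitor: compound 1 `Cc1nc2c3ccccc3ccc2c2nc3c(ccc4ccccc43)c(-c3cccc([N+](=O)[O-])c3)c12` gives 25500 nM. Compound 2 `Cc1nc2c3ccccc3ccc2c2nc3c(ccc4ccccc43)c(-c3cccnc3)c12` gives 3960 nM.

Compound 2 holds the lower of the two numbers, set apart from compound 1 by the step of a 6.4-fold lower number from compound 1 to compound 2 (0.81 log units; beyond the scatter). Compound 3 `Cc1nc2c3ccccc3ccc2c2nc3c(ccc4ccccc43)c(-c3nccnc3N)c12` differs from compound 2 in one place: 3-aminopyrazin-2-yl in place of pyridin-3-yl on an aromatic carbon. Among the compounds with values here, only that one measured step touches this site, and it swaps a different pair of groups, so it offers weak guidance. No step beyond the scatter is therefore expected from compound 2 to compound 3: a 1.0-fold higher number from compound 2 to compound 3 (0.00 log units; within the scatter). Compound 3 is estimated at 4000 nM, expected to fall between 1500 nM and 11000 nM.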

Compound 3, half-maximal inhibitory concentration: 2260 nM
Estimate against measurement, compound 3: 1.8-fold (0.25 log units) above; measured number inside the range.
By their numbers in this assay, from the lowest: compounds 3 and 2 (each within the scatter of the next); then compound 1.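

In this assay, the carbon opposite the ring nitrogen accepts a larger ring with more nitrogens and a hydrogen-bond donor without a clear shift: the swap gives a 1.8-fold lower number from compound 2 to compound 3 (0.24 log units; within the scatter), so 3-aminopyrazin-2-yl and pyridin-3-yl cannot be told apart here. Against 3-nitrophenyl, the same group gives an 11-fold lower number from compound 1 to compound 3 (1.05 log units; beyond the scatter), which places compound 3 with compound 2, clear of compound 1. Nothing available explains these numbers.

Still open, from the compounds shown here alone, is whether the amine contributes anything on its own. Plain pyrazin-2-yl and 3-aminophenyl at this carbon would help separate the amine from the ring nitrogens.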